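Adding a Methoxy Group: Compound 4 Expected Near Compound 3

The source may report more compounds than this note shows. Statements on the series, on what has been measured and on what is new or still open speak of the compounds shown alone.

Compound 1, `Cc1cc(O)c(C2=NN(c3ccc(S(N)(=O)=O)cc3)C(c3ccccc3Cl)C2)cc1Cl`: 2810 nM
Compound 2, `Cc1cc(O)c(C2=NN(c3ccc(S(N)(=O)=O)cc3)C(/C=C/c3ccccc3)C2)cc1Cl`: 3380 nM
Compound 3, `COc1ccc(C2CC(c3cc(Cl)c(C)cc3O)=NN2c2ccc(S(N)(=O)=O)cc2)cc1OC`: 3100 nM

The three measured compounds differ only in the group on a saturated ring carbon of the shared core, and in a functional assay on T47D cells (Homo sapiens) for antiproliferative activity, with a stated time of 48 h (on this read-out lower numbers stand for stronger inhibition of growth and higher numbers for weaker inhibition of growth), their numbers lie close together: a 1.2-fold higher number from compound 1 to compound 2 (0.08 log units; within the scatter), a 1.1-fold higher number from compound 1 to compound 3 (0.04 log units; within the scatter) and a 1.1-fold lower number from compound 2 to compound 3 (0.04 log units; within the scatter). Compound 3 is therefore not separated from either of the others beyond the scatter. Compound 4, `COc1ccc(C2CC(c3cc(Cl)c(C)cc3O)=NN2c2ccc(S(N)(=O)=O)cc2)c(OC)c1OC`, differs from compound 3 by methoxy in place of hydrogen on an aromatic carbon. Going by the values given here, no measured step touches this change; all three concern exchanging the whole group on the saturated carbon, and each stayed within the scatter, so this assay has so far been little moved by what sits there. Compound 4 is accordingly expected to show a 1.0-fold higher number from compound 3 to compound 4 (0.01 log units; within the scatter), nothing beyond the scatter. The value of compound 4 in this assay is estimated at 3200 nM, within 1500 nM to 7000 nM.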

Compound 4, concentration for 50% growth inhibition: 2280 nM
Estimate against measurement, compound 4: 1.4-fold (0.15 log units) above, and the stated range covers the measured number.
By their numbers in this assay, from the lowest: compounds 4, 1, 3 and 2 (each within the scatter of the next).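

In this assay, methoxy in place of hydrogen on an aromatic carbon, ortho to a large group, gives a 1.4-fold lower number from compound 3 to compound 4 (0.13 log units; within the scatter) and is the first change shown on this ring itself, not an exchange of the whole group, yet it also stays within the scatter. The 2,3,4-trimethoxyphenyl group likewise gives a 1.5-fold lower number from compound 2 to compound 4 (0.17 log units; within the scatter) and a 1.2-fold lower number from compound 1 to compound 4 (0.09 log units; within the scatter), so all the steps shown remain within the scatter. Nothing available here accounts for these small differences.

From the compounds shown here alone, whether an amine or a carboxylic acid in place of this methoxy, or a longer chain such as butoxy, would shift the number in this assay beyond the scatter remains open.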